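A few compounds are considered here, and "the series" means these few. Any claim that something is new, unique, unknown or untested is made for them only; others in the source may bear on it.

Measured compounds:
Compound 1 `C#CC(=O)N1C(CCCCC)SC[C@@H]1C(=O)OCC`: 2000 nM
Compound 2 `C#CC(=O)N1C(c2ccccc2F)SC[C@@H]1C(=O)OCC`: 1700 nM
Compound 3 `C#CC(=O)N1C(C(CC)CCCC)SC[C@@H]1C(=O)OCC`: 1600 nM

In a functional assay on MV cells (Homo sapiens) for inhibition, read by sulforhodamine B assay (a higher number here means a weaker inhibitor, a lower number a stronger inhibitor), compound 1 gives the highest of the three numbers, yet all three lie within the scatter of one another. The step of a 1.2-fold lower number from compound 1 to compound 2 (0.07 log units; within the scatter) and the step of a 1.3-fold lower number from compound 1 to compound 3 (0.10 log units; within the scatter) show that neither swapping the chain for an aromatic group nor branching the chain moved the read-out, and a 1.1-fold lower number from compound 2 to compound 3 (0.03 log units; within the scatter) confirms that the two variants sit together.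

Compound 4 `C#CC(=O)N1C(CC(C)CC(C)(C)C)SC[C@@H]1C(=O)OCC` carries the change 1,3,3-trimethylbutyl in place of butyl on a saturated chain carbon bound to a saturated ring carbon relative to compound 1. The most closely related measured step is the branching in a 1.3-fold lower number from compound 1 to compound 3 (0.10 log units; within the scatter), which stayed within the scatter; the larger exchange in a 1.2-fold lower number from compound 1 to compound 2 (0.07 log units; within the scatter) did as well. Compound 4 is therefore expected to show no step beyond the scatter, with a 1.1-fold lower number from compound 1 to compound 4 (0.05 log units; within the scatter) as the estimated outcome. Compound 4 is estimated at 1800 nM, with a range from 900 nM to 3600 nM.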

Compound 4, half-maximal inhibitory concentration: 1100 nM
Compound 4: middle estimate off by 1.6-fold (0.21 log units), on the high side, and the stated range covers the measured number.
By their numbers in this assay, from the lowest: compounds 4, 3, 2 and 1 (each within the scatter of the next).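

In this assay, putting 1,3,3-trimethylbutyl in place of butyl on a saturated chain carbon bound to a saturated ring carbon gives a step (a 1.8-fold lower number from compound 1 to compound 4 (0.26 log units; within the scatter)) that remains within the scatter. This position therefore tolerates a group of 7 heavy atoms in place of one of 4 without a clear separation from compound 1, extending what the smaller branching in compound 3 showed. Nothing available explains why this step is larger than the earlier steps from compound 1.

Going by these compounds, it remains open whether an amine or a carboxylic acid in place of these hydrocarbon groups would move the number beyond the scatter. On these data alone, it is also open whether a longer chain, such as decyl, would do so.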